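The source may report more compounds than this note shows. Statements on the series, on what has been measured and on what is new or still open speak of the compounds shown alone.

Measured so far:
Compound 1 `O=C1CC(N2C(=O)/C(=C/C(Cl)=C/c3ccc([N+](=O)[O-])cc3)SC2=S)C(=O)N1c1ccc(Cl)cc1` gives 6450 nM
Compound 2 `C=CCOc1ccccc1/C=C1\SC(=S)N(C2CC(=O)N(c3ccc(Cl)cc3)C2=O)C1=O` gives 98600 nM

Both values come from a functional assay on MDA-MB-231 cells (Homo sapiens) for inhibition, read by MTT assay, with a stated time of 72 h (on this read-out lower numbers stand for stronger inhibition of growth and higher numbers for weaker inhibition of growth), and the gap between them lies beyond the scatter. Compound 2 holds the higher of the two numbers, so it is the weaker of the pair on this read-out.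

Compound 3 `C=CCOc1cccc(/C=C2\SC(=S)N(C3CC(=O)N(c4ccc(Cl)cc4)C3=O)C2=O)c1` keeps the atoms of compound 2 and joins them differently: 3-(allyloxy)phenyl in place of 2-(allyloxy)phenyl on a double-bonded chain carbon bound to a double-bonded ring carbon in words, 3-(allyloxy)phenyl in place of 2-(allyloxy)phenyl on a double-bonded chain carbon bound to a double-bonded ring carbon. Among the measured compounds shown here, no measured pair differs in one place, so the series gives no direct guide to this step. For the measured compounds named here, from compound 2 a modest move toward a lower number is expected because compound 2 gives 98600 nM, the higher of only two values seen. The expected change is a 2.5-fold lower number from compound 2 to compound 3 (0.39 log units; beyond the scatter) as an estimate with wide uncertainty. Compound 3 is estimated at 40000 nM with 10000 nM to 120000 nM as the expected range.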

Compound 3, concentration for 50% growth inhibition: > 100000 nM
Compound 3 ended at the assay's limit; the forecaster's own chance of this, stated with the estimate: 10%; middle value at least 2.5-fold (0.39 log units) from the limit.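

In this assay compound 3 gives > 100000 nM, which is a limit of the assay and not a number. Replacing 2-(allyloxy)phenyl with 3-(allyloxy)phenyl on a double-bonded chain carbon bound to a double-bonded ring carbon gives an at least 1.0-fold higher number from compound 2 to compound 3 (0.00 log units; that floor lies within the scatter), so this first one-place comparison in the series shows no measured gain in growth inhibition from this change, while the true size of the step stays unfixed. The reading for compound 3 therefore marks the end of the usable range at this position rather than a measured level: the limit of > 100000 nM in this assay, at which 1 of the 3 values shown sits.

Going by these compounds, the true distance between compound 2 and compound 3 remains open, as a limit cannot give it. Also open, on these data alone, is whether a methoxy group or a carboxylic acid in place of the allyloxy group would give a number inside the range of this assay.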